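Swapping a sulfur linker for oxygen on the shared core

The source may report more compounds than this note shows. Statements on the series, on what has been measured and on what is new or still open speak of the compounds shown alone.

In an ADME assay on isolated protein for pharmacokinetics, with UDP-glucuronosyltransferase 1A9 (Homo sapiens) as the target, read by LC-MS, with a stated time of 60 min, at 37 degrees C, tested at 1 uM, in the presence of a further agent that is not named here (on this read-out higher numbers stand for a longer-lived compound and lower numbers for a shorter-lived compound), compound 1 `NS(=O)(=O)CC(=O)NCCSc1nonc1/C(=N/O)Nc1ccc(F)c(Br)c1` gives 0.758 h, while compound 2 `NS(=O)(=O)NCCSc1nonc1/C(=N/O)Nc1ccc(F)c(Br)c1` gives 0.183 h, the lowest of the two numbers; the change a 4.1-fold lower number from compound 1 to compound 2 (0.62 log units; beyond the scatter) lies beyond the scatter. Compound 3 `NS(=O)(=O)NCCOc1nonc1/C(=N/O)Nc1ccc(F)c(Br)c1` differs from compound 2 by 2-(sulfamoylamino)ethoxy in place of (2-(sulfamoylamino)ethyl)sulfanyl on an aromatic carbon. Among the compounds with values here, the only measured step concerns a different part of the molecule, so no measured step bears on this change, and nothing points to a direction. The expected step is a 1.1-fold higher number from compound 2 to compound 3 (0.04 log units; within the scatter), within the scatter. The estimate for compound 3 is 0.2 h, in the range 0.08 h to 0.5 h.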

Compound 3, half-life: 0.0483 h
For compound 3 the middle estimate is 4.1-fold (0.62 log units) above the measured one, and the stated range ends above it.
By their numbers in this assay, from the lowest: compound 3; then compound 2; then compound 1.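

In this assay, the atom that joins the chain to the aromatic carbon of the shared core clearly counts: the oxygen-linked chain 2-(sulfamoylamino)ethoxy in place of the sulfur-linked (2-(sulfamoylamino)ethyl)sulfanyl brings a 3.8-fold lower number from compound 2 to compound 3 (0.58 log units; beyond the scatter), with the rest of the molecule unchanged. The earlier step showed a change only at the other end of the chain. No measurement here accounts for this drop. Still open, on these data alone, is where an amine nitrogen in this place would fall, and whether the same swap would also lower the number for compound 1.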